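A few compounds are considered here, and "the series" means these few. Any claim that something is new, unique, unknown or untested is made for them only; others in the source may bear on it.

Measured compounds:
- compound 1, `COc1ccc(NC(=O)c2ccccn2)c(CN2C(=O)c3ccccc3C2=O)c1`: 1400 nM
- compound 2, `O=C(Nc1ccc(F)cc1CN1C(=O)c2ccccc2C1=O)c1ccccn1`: 1500 nM
- compound 3, `O=C(Nc1ccc(Cl)cc1CN1C(=O)c2ccccc2C1=O)c1cccnc1`: 35000 nM

All three were tested in an assay on CHO cells for positive allosteric modulation of metabotropic glutamate receptor 5 (Homo sapiens), read by FLIPR; a higher number here means that more compound is needed for the effect, a lower number that less compound is needed. Compound 3 stands at the highest of the three numbers; its nearest neighbour is compound 2, which gives 1500 nM, and the furthest is compound 1, which gives 1400 nM. Both of those gaps lie beyond the scatter, so compound 3 needs clearly more compound for the same effect than either. Going by the values given here, the only step between measured compounds that differ in one place, a 1.1-fold higher number from compound 1 to compound 2 (0.03 log units; within the scatter), concerns a change on the aromatic ring of the aniline part and is within the scatter.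

Compound 4, `O=C(Nc1ccc(Cl)cc1CN1C(=O)c2ccccc2C1=O)c1ccccc1C(F)(F)F`, differs from compound 3 in the group attached to the amide carbonyl: 2-(trifluoromethyl)phenyl in place of pyridin-3-yl on a carbonyl carbon. Among the compounds with values here, no measured step addresses this part of the molecule, so nothing measured here bears directly on it. The two amide groups in compounds 1 and 2 differ from that of compound 3 in the aromatic ring on the carbonyl carbon, which is where the large gap to compound 3 appears, and compound 4 changes that same ring again. In this assay the step from compound 3 to compound 4 is expected to be a 3.5-fold lower number from compound 3 to compound 4 (0.54 log units; beyond the scatter), a guess with wide uncertainty. Compound 4 is therefore estimated at 10000 nM, within a range of 2500 nM to 40000 nM.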

Compound 4, half-maximal effective concentration: 5700 nM
For compound 4 the middle estimate is 1.8-fold (0.24 log units) above the measured one, within the range that was stated.
By their numbers in this assay, from the lowest: compounds 1 and 2 (each within the scatter of the next); then compound 4; then compound 3.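

In this assay, going by these compounds alone, the exchange on the carbonyl carbon whose other neighbour is the amide-type nitrogen gives a 6.1-fold lower number from compound 3 to compound 4 (0.79 log units; beyond the scatter), the first one-place step at this position, and it shows that the group here can shift the amount of compound needed. The pyridin-3-yl group that leaves has a ring nitrogen and a hydrogen-bond acceptor, while the 2-(trifluoromethyl)phenyl group that enters has a carbon-only ring and no acceptor, so neither that ring nitrogen nor that acceptor is required for compound 4 to act at a lower number than compound 3. Still, the ring nitrogen leaves and the trifluoromethyl group enters in a single step, and no measured evidence accounts for the shift or divides it between the two.

A plain phenyl group on this carbonyl carbon, or a phenyl group carrying a methyl or a nitrile, would help show how much of the step belongs to each part of the exchange. Going by these compounds, it also remains open whether the same exchange would give a step of similar size in a compound with fluoro or methoxy in place of the chloro.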